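Sulfonyl in Place of Trifluoromethyl on a Shared Core

The source may report more compounds than this note shows. Statements on the series, on what has been measured and on what is new or still open speak of the compounds shown alone.

The series is followed in a physicochemical assay for solubility, at pH 2; a lower number here means a less soluble compound, a higher number a more soluble compound. Compound 1, `CS(=O)(=O)c1cncc(-c2ccc3ncc(-c4ccc(S(=O)(=O)C5CC5)cc4)n3n2)c1`, is one of two measured members. For compound 1 the reading is a limit of the assay rather than a number, < 5000 nM. Compound 2, `CS(=O)(=O)c1ccc(-c2cnc3ccc(-c4cncc(C(F)(F)F)c4)nn23)cc1`, shares the core and carries a trifluoromethyl group. For compound 2 the reading is likewise a limit and not a number, < 5000 nM. Both measured values therefore sit at the limit of < 5000 nM in this assay, at which 2 of the 2 values shown sit, so compound 2 cannot be placed above or below compound 1 on the numbers shown.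

Compound 3, `CS(=O)(=O)c1ccc(-c2cnc3ccc(-c4cncc(S(C)(=O)=O)c4)nn23)cc1`, is not yet measured. It differs from compound 2 by methylsulfonyl in place of trifluoromethyl on an aromatic carbon. For the measured compounds named here, no measured pair in this set shows what such a change does in this assay, so any expectation rests only on where compound 2 stands. Compound 3 is expected to change by a step that the limit leaves unreadable from compound 2 to compound 3 from compound 2, a step that need not exceed the scatter. Compound 3 is estimated at 4000 nM, within 1000 nM to 16000 nM, with a real chance that the assay again reports only a limit.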

Compound 3, solubility: < 5000 nM
Compound 3: no number, only a limit; the forecaster's own chance of this, stated with the estimate: 55%; the middle value is on the limit's open side.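

In this assay compound 3 again gives only a limit, so neither its step from compound 2 nor its step from compound 1 can be read: the limit of < 5000 nM in this assay, at which 3 of the 3 values shown sit.

The compounds shown leave open whether methylsulfonyl in place of trifluoromethyl on an aromatic carbon, or methyl in place of cyclopropyl on a sulfonyl sulfur, changes the reading at all.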